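The source may report more compounds than this note shows. Statements on the series, on what has been measured and on what is new or still open speak of the compounds shown alone.

Measured compounds:
compound 1 `Brc1ccc(NCc2nc3ccc(Br)cc3[nH]2)cc1` gives 16.6%
compound 2 `Cc1ccc(NCc2nc3ccc(Br)cc3[nH]2)cc1` gives 16.6%
compound 3 `c1ccc(NCc2nc3ccccc3[nH]2)cc1` gives 38.8%

In a functional assay on the whole organism (strain albino) for inhibition, with Rattus norvegicus as the target, read by paw edema, with a stated time of 180 min, at a dose of 100 mg/kg by the oral route (a higher number here means more inhibition at the dose given (going by the name of the read-out), a lower number less inhibition), compound 1 stands level with compound 2 at the digits shown, the two together the lowest of the three numbers; compound 3 stands a good deal higher, beyond the scatter. Among the measured compounds shown here, the only measured step, no change at the digits printed from compound 1 to compound 2 (within the scatter), was a methyl in place of bromo on an aromatic carbon, and it left the read-out unchanged within the scatter.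

Compound 4 `O=[N+]([O-])c1ccc2nc(CNc3ccc(Br)cc3)[nH]c2c1` is the step from compound 1 that puts (nitro in place of bromo on an aromatic carbon). For the measured compounds named here, that step swaps a different bromo from the one that the step from compound 1 to compound 2 touched, so the measured step bears on it only loosely: it shows that swapping one bromo of compound 1 did nothing within the scatter. Going by the values given here, no measured step exchanges bromo for nitro. The expectation is therefore a step of about a number 3.4 percentage points higher from compound 1 to compound 4 (within the scatter), that is, none beyond the scatter. Compound 4 is estimated at 20%, with a range from 5% to 40%.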

Compound 4, a percentage reported as inhibition, in the whole organism at one dose (the size of the read-out at that dose, not a potency): 22.2%
Compound 4: middle estimate off by 2.2 percentage points, on the low side; measured number inside the range.
By their numbers in this assay, from the lowest: compounds 1, 2 and 4 (each within the scatter of the next); then compound 3.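

In this assay, the bromo on the six-membered aromatic ring of carbon only, part of the fused system of two rings, now has a measured exchange of its own: nitro in its place gives a number 5.6 percentage points higher from compound 1 to compound 4 (within the scatter), so this larger group leaves the read-out unmoved beyond the scatter. Set beside the earlier exchange of the other bromo, no change at the digits printed from compound 1 to compound 2 (within the scatter), this means that each bromo of compound 1 has been replaced once, and neither single exchange has brought the read-out up to the level of compound 3. No measurement is at hand that would account for the nitro result.

Going by these compounds, whether an amine or a carboxylic acid on this same aromatic carbon would stay within the scatter of compound 1 remains open. So does the question of which single exchange, if any, separates compound 3 from the others, as it differs from each of them in more than one place.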